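The compounds below may be only part of what the source reports. "The series", "measured", "known", "first", "only" and "open" are said of these compounds alone.

Values in a functional assay on NCI-H460 cells (Homo sapiens) for inhibition, read by CCK-8 assay, with a stated time of 48 h; on this read-out higher numbers stand for weaker inhibition and lower numbers for stronger inhibition:
compound 1 `O=C(NC(=S)Nc1ccc(F)cc1)c1cn(-c2ccccc2)nc1-c1ccccc1`: 4210 nM
compound 2 `COc1ccc(-c2nn(-c3ccccc3)cc2C(=O)NC(=S)Nc2ccc(F)cc2)cc1`: 3050 nM

Compound 2 sits at the lower of the two numbers shown in this assay, but its only neighbour is compound 1 and the gap a 1.4-fold lower number from compound 1 to compound 2 (0.14 log units; within the scatter) lies within the scatter, so the two compounds are not distinguished by these data. Compound 3 `Cc1ccc(-c2nn(-c3ccccc3)cc2C(=O)NC(=S)Nc2ccc(F)cc2)cc1` has not yet been measured. Its change from compound 2 is methyl in place of methoxy on an aromatic carbon; the rest of the shared core is untouched. Going by the values given here, the one measured step at this position is a 1.4-fold lower number from compound 1 to compound 2 (0.14 log units; within the scatter), which stayed within the scatter, and no step exchanging methoxy for methyl has been measured. On that basis the step of a 1.0-fold higher number from compound 2 to compound 3 (0.02 log units; within the scatter) is expected to remain within the scatter, with no direction predicted beyond it. Compound 3 is therefore estimated at 3200 nM in this assay, with a range from 1500 nM to 7000 nM.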

Compound 3, half-maximal inhibitory concentration: 3980 nM
Estimate against measurement, compound 3: 1.2-fold (0.09 log units) below; the measured number falls inside the stated range.
By their numbers in this assay, from the lowest: compounds 2, 3 and 1 (each within the scatter of the next).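

In this assay the exchange of 4-methoxyphenyl for 4-methylphenyl gives a 1.3-fold higher number from compound 2 to compound 3 (0.12 log units; within the scatter) and removes one heavy atom and the only hydrogen-bond acceptor of the leaving group, yet the read-out does not separate the two compounds. The comparison with hydrogen now covers a second group, since methyl in place of hydrogen gives a 1.1-fold lower number from compound 1 to compound 3 (0.02 log units; within the scatter) on the same aromatic carbon, para to a large group, so hydrogen, methoxy and methyl are not distinguished at this position. The data offer no evidence that could explain this lack of separation.

Going by these compounds, whether any group at this position can produce a step beyond the scatter stays open, for example an amine, a carboxylic acid or a longer chain. Also open, on these data alone, is whether methoxy and methyl stay indistinguishable when another part of the shared core is changed.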